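The compounds below may be only part of what the source reports. "The series", "measured", "known", "first", "only" and "open" are said of these compounds alone.

Compound 3 `CCC[C@@H](CCO)Nc1nc(N)nc(C)c1Cc1ccc(CNCCC(N)=O)cc1OC` is one of three close relatives of a shared core that all sit at the edge of what can be measured. In an assay on HEK293 cells for agonist activity at Toll-like receptor 8 (Homo sapiens) (a higher number here means that more compound is needed for the effect, a lower number that less compound is needed), compound 3 gives > 10000 nM, a limit rather than a number. Compound 1 `CCC[C@@H](CCO)Nc1nc(N)nc(C)c1Cc1ccc(CN(C)CC(N)=O)cc1OC` gives > 10000 nM in this assay, also a limit. Compound 2 `CCC[C@@H](CCO)Nc1nc(N)nc(C)c1Cc1ccc(CNCC(N)=O)cc1OC` gives > 10000 nM, again a limit. Because (the limit of > 10000 nM in this assay, at which 3 of the 3 values shown sit), the steps a step that the two limits leave unreadable from compound 1 to compound 2, a step that the two limits leave unreadable from compound 1 to compound 3 and a step that the two limits leave unreadable from compound 2 to compound 3 cannot be read. Compound 4 `CCC[C@@H](CCO)Nc1nc(N)nc(C)c1Cc1ccc(Cn2ccnc2)cc1OC` carries 1H-imidazol-1-yl in place of (2-carbamoylethyl)amino on a saturated chain carbon bound to an aromatic carbon. Among the compounds with values here, no measured step bears on this change, so nothing more than the limit can be inferred. The expected step of an at least 1.2-fold lower number from compound 3 to compound 4 (0.09 log units; that floor lies within the scatter) is therefore uncertain, and compound 4 is estimated at 8000 nM, between 800 nM and 20000 nM.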

Compound 4, half-maximal effective concentration: 4900 nM
Compound 4: middle estimate off by 1.6-fold (0.21 log units), on the high side, within the range that was stated.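

Within the data shown here, compound 4, with 1H-imidazol-1-yl, gives the first real number in this assay, whereas the steps among compound 1, compound 2 and compound 3 cannot be read. The change to this group on the saturated chain carbon bound to an aromatic carbon gives an at least 2.0-fold lower number from compound 3 to compound 4 (0.30 log units; that floor lies within the scatter), an at least 2.0-fold lower number from compound 2 to compound 4 (0.30 log units; that floor lies within the scatter) and an at least 2.0-fold lower number from compound 1 to compound 4 (0.30 log units; that floor lies within the scatter). Each is only a floor, and the true size of each step stays unknown because the other end rests on a limit: the limit of > 10000 nM in this assay, at which 3 of the 4 values shown sit.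

On these data alone, it remains open whether another aromatic ring, such as 1H-pyrazol-1-yl, or a plain amine, such as dimethylamino, would also give a number at this place in this assay.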